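Thiazole regiochemistry on the cyclopropyl arm

The source may hold more compounds than are shown below. What is called first, only, known or untested is meant among the compounds shown, and "the series" means these compounds.

Compound 3 `CC[C@H](C)[C@H](N)CN(C(=O)[C@@H]1C[C@H]1c1nc(C)c(C)s1)c1ccc(-c2ccccc2)cc1` gives 3600 nM in a functional assay for agonist activity at G protein-coupled receptor 88 (Homo sapiens), read by HTRF and cAMP accumulation (a higher number here means that more compound is needed for the effect, a lower number that less compound is needed), the highest of the two plain numbers in this set. Compound 1 `CC[C@H](C)[C@H](N)CN(C(=O)[C@@H]1C[C@H]1c1cccc(C#N)c1)c1ccc(-c2ccccc2)cc1` gives 1600 nM in this assay; the step runs a 2.3-fold higher number from compound 1 to compound 3 (0.35 log units; beyond the scatter). Compound 2 `CC[C@H](C)[C@H](N)CN(C(=O)[C@@H]1C[C@H]1C1CCCCC1)c1ccc(-c2ccccc2)cc1` returns only a limit in this assay, > 25000 nM (the limit of > 25000 nM in this assay, at which 1 of the 3 values shown sits). The step of an at least 15-fold higher number from compound 1 to compound 2 (1.19 log units; beyond the scatter) and the step of an at least 6.9-fold lower number from compound 2 to compound 3 (0.84 log units; beyond the scatter) show that the cyclohexyl group is far less tolerated than either aromatic group. Compound 4 `CC[C@H](C)[C@H](N)CN(C(=O)[C@@H]1C[C@H]1c1csc(C)n1)c1ccc(-c2ccccc2)cc1` differs from compound 3 by 2-methyl-1,3-thiazol-4-yl in place of 4,5-dimethyl-1,3-thiazol-2-yl on a saturated ring carbon. Both compounds carry a methylated thiazolyl group at the same place, so the measured steps give no direct guide; the nearest aromatic-to-aromatic comparison, compound 1 to compound 3, was modest. A step of roughly a 1.1-fold higher number from compound 3 to compound 4 (0.05 log units; within the scatter) is expected, within the scatter. Compound 4 is estimated at 4000 nM, range 1500 nM to 12000 nM.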

Compound 4, half-maximal effective concentration: 1500 nM
For compound 4 the middle estimate is 2.7-fold (0.43 log units) above the measured one, and the stated range covers the measured number.
By their numbers in this assay, from the lowest: compounds 4 and 1 (each within the scatter of the next); then compound 3. At a limit, above all of these: compound 2.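

Exchanging 4,5-dimethyl-1,3-thiazol-2-yl for 2-methyl-1,3-thiazol-4-yl gives a 2.4-fold lower number from compound 3 to compound 4 (0.38 log units; beyond the scatter), so in this assay two methylated thiazolyl groups are not interchangeable on this cyclopropyl carbon. The 2-methyl-1,3-thiazol-4-yl group also holds level with 3-cyanophenyl, at a 1.1-fold lower number from compound 1 to compound 4 (0.03 log units; within the scatter), so a five-membered aromatic ring can do as well here as the substituted phenyl. The gap to cyclohexyl widens to an at least 16-fold lower number from compound 2 to compound 4 (1.22 log units; beyond the scatter), with compound 2 still only a limit: the limit of > 25000 nM in this assay, at which 1 of the 4 values shown sits.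

This change alters the attachment point and the methyl pattern together, and the two effects remain unseparated. From the compounds shown here alone, how an unsubstituted 1,3-thiazol-4-yl or a 2-amino-1,3-thiazol-4-yl group would read here remains open.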